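Compound 4 in the PAK 4 series: working estimate

A few compounds are considered here, and "the series" means these few. Any claim that something is new, unique, unknown or untested is made for them only; others in the source may bear on it.

Measured compounds:
- compound 1, `OCCNc1nc(Nc2ccccc2)nc2[nH]ccc12`: 86.9%
- compound 2, `c1ccc(Nc2nc(N3CCNCC3)c3cc[nH]c3n2)cc1`: 89.6%
- compound 3, `N[C@H]1CCCN(c2nc(Nc3cccc(Cl)c3)nc3[nH]ccc23)C1`: 38.3%

All three were run in an assay on isolated protein for inhibition of serine/threonine-protein kinase PAK 4 (Homo sapiens), read by filter binding, with a stated time of 20 min, tested at 2 uM; on this read-out higher numbers stand for more inhibition at the one concentration tested (going by the name of the read-out) and lower numbers for less inhibition. Compound 3 stands lowest of the three numbers: its value sits beyond the scatter below compound 1 and below compound 2. Compound 1 and compound 2 differ at the aromatic carbon of the shared core, and the step of a number 2.7 percentage points higher from compound 1 to compound 2 (within the scatter) lies within the scatter.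

Compound 4, `NCC1CCCN(c2nc(Nc3cccc(Cl)c3)nc3[nH]ccc23)C1`, is not yet measured. It differs from compound 3 in one place: 3-(aminomethyl)piperidin-1-yl in place of 3-aminopiperidin-1-yl on an aromatic carbon. Going by the values given here, the only measured step, from compound 1 to compound 2, concerns a different pair of groups at the same kind of position, and was within the scatter; it gives no direct guide to this change, and no measured pair tests an extra carbon in the substituent chain. With nothing pointing in either direction, the step of a number 1.7 percentage points higher from compound 3 to compound 4 (within the scatter) is expected to stay within the scatter. Compound 4 is therefore estimated at 40%, with a range from 20% to 65%.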

Compound 4, a percentage reported as inhibition, at one concentration (the size of the read-out at that concentration, not a potency): 61%
Beside the measured number, compound 4's estimate is 21 percentage points below it, within the range that was stated.
By their numbers in this assay, from the lowest: compound 3; then compound 4; then compounds 1 and 2 (each within the scatter of the next).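

In this assay, the position on an aromatic carbon next to the ring nitrogen responds to a small change within the substituent: 3-(aminomethyl)piperidin-1-yl in place of 3-aminopiperidin-1-yl gives a number 22.7 percentage points higher from compound 3 to compound 4 (beyond the scatter). Going by these compounds alone, the only earlier step at this kind of position, a number 2.7 percentage points higher from compound 1 to compound 2 (within the scatter), swapped one group for a different one without leaving the scatter, so this pair is the first to show that the position can separate two closely related groups. No measurement on hand explains the size or direction of this step.

The step also combines the added carbon with the loss of the defined stereocentre, and the compounds shown do not separate the two. Still open, going by these compounds, is how a longer aminoalkyl chain, or a hydroxymethyl or dimethylamino group in place of the primary amine, would read on the same piperidine.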